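Substituent on the ring-nitrogen aryl: compound 4

The source may report more compounds than this note shows. Statements on the series, on what has been measured and on what is new or still open speak of the compounds shown alone.

Measured compounds in a functional assay on HOS cells (Homo sapiens) for inhibition, read by CCK-8 assay, with a stated time of 72 h, tested at 1 uM; a lower number here means less inhibition, a higher number more inhibition at the concentration tested (going by the name of the read-out):
compound 1 `O=C(NCCCCc1ccccc1)c1cccc(C2SCC(=O)N2c2cccc(F)c2)c1` gives 84%
compound 2 `COc1cc(F)ccc1N1C(=O)CSC1c1cccc(C(=O)NCCCCc2ccccc2)c1` gives 81%
compound 3 `O=C(NCCCCc1ccccc1)c1cccc(C2SCC(=O)N2c2ccccc2)c1` gives 55%

In this assay compound 3 holds the lowest of the three numbers, with both other compounds standing beyond the scatter above it. Compound 4 `CC(F)(F)c1cccc(N2C(=O)CSC2c2cccc(C(=O)NCCCCc3ccccc3)c2)c1` differs from compound 3 by 1,1-difluoroethyl in place of hydrogen on an aromatic carbon. Among the measured compounds shown here, two measured steps bear on this change: a number 29 percentage points lower from compound 1 to compound 3 (beyond the scatter) and a number 26 percentage points lower from compound 2 to compound 3 (beyond the scatter). Both show the unsubstituted ring of compound 3 falling well short of a substituted one, and a single fluoro in compound 1 gave the larger of the two gaps. For the measured compounds named here, a 1,1-difluoroethyl entering on an aromatic carbon meta to a large group is therefore expected to raise inhibition in this assay, by an estimated a number 21 percentage points higher from compound 3 to compound 4 (beyond the scatter), though no measured step carries this exact group and the range is kept wide. Compound 4 is estimated at 76%, between 58% and 90%.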

Compound 4, a percentage reported as inhibition, at one concentration (the size of the read-out at that concentration, not a potency): 23%
Beside the measured number, compound 4's estimate is 53 percentage points above it; the whole stated range lies above it.
By their numbers in this assay, from the lowest: compound 4; then compound 3; then compounds 2 and 1 (each within the scatter of the next).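

In this assay a substituent on the ring-nitrogen aryl no longer means a gain over the unsubstituted phenyl: 1,1-difluoroethyl in place of hydrogen gives a number 32 percentage points lower from compound 3 to compound 4 (beyond the scatter) and puts this position on record as able to lose inhibition as well. The outcome turns on the group, since replacing fluoro with 1,1-difluoroethyl gives a number 61 percentage points lower from compound 1 to compound 4 (beyond the scatter) and the change on the amide-type ring nitrogen gives a number 58 percentage points lower from compound 2 to compound 4 (beyond the scatter) in the same direction. No measurement at hand accounts for this fall. Open, on these data alone, is where methyl or trifluoromethyl on this aromatic carbon would fall relative to fluoro and 1,1-difluoroethyl. As far as these compounds go, an amine or a carboxylic acid at this place is equally open.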